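A few compounds are considered here, and "the series" means these few. Any claim that something is new, unique, unknown or untested is made for them only; others in the source may bear on it.

Working notes on the series. The compounds share the core of compound 1 `O=C(CN1CCN(c2ccccc2)CC1)N(c1ccccc1)c1ccccc1`, with the aryl group on the ring nitrogen varied. In a functional assay on the whole organism (strain Swiss albino) for inhibition, with Mus musculus as the target, with stated times of 30 min, 10 min and 20 min (a higher number here means that more compound is needed for the effect, a lower number that less compound is needed), compound 1 gives 27 mg/kg. Compound 2 `Cc1cccc(N2CCN(CC(=O)N(c3ccccc3)c3ccccc3)CC2)c1C` reaches only a limit of the assay, > 30 mg/kg, and no number. Compound 3 `COc1ccccc1N1CCN(CC(=O)N(c2ccccc2)c2ccccc2)CC1` gives 12.7 mg/kg; among the numbers seen this is the lowest of two, the nearest being compound 1. The third entry, that of compound 2, is a limit (the limit of > 30 mg/kg in this assay, at which 1 of the 3 values shown sits).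

Compound 4 `O=C(CN1CCN(c2cccc(Cl)c2)CC1)N(c1ccccc1)c1ccccc1` differs from compound 3 in one place: 3-chlorophenyl in place of 2-methoxyphenyl on an amine nitrogen in a ring. For the measured compounds named here, two measured steps bear on it. The gain of the methoxy is seen in a 2.1-fold lower number from compound 1 to compound 3 (0.33 log units; beyond the scatter), and the aryl exchange in an at least 2.3-fold lower number from compound 2 to compound 3 (0.37 log units; beyond the scatter); the remaining step, an at least 1.1-fold higher number from compound 1 to compound 2 (0.04 log units; that floor lies within the scatter), sits at the floor set by the limit. Going by the values given here, the methoxy now leaves, and no measured step speaks to a 3-chlorophenyl group. A modest step back towards compound 1 is therefore expected, a 1.7-fold higher number from compound 3 to compound 4 (0.24 log units; within the scatter). Compound 4 is estimated at 22 mg/kg, with a range of 10 mg/kg to 45 mg/kg.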

Compound 4, dose for half-maximal effect: 18 mg/kg
For compound 4 the middle estimate is 1.2-fold (0.09 log units) above the measured one, and the stated range covers the measured number.
By their numbers in this assay, from the lowest: compounds 3, 4 and 1 (each within the scatter of the next, the first and the last beyond it). At a limit, above all of these: compound 2.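

The 3-chlorophenyl group on the amine nitrogen in a ring leaves no step beyond the scatter towards either of the compounds it can be read against: a 1.4-fold higher number from compound 3 to compound 4 (0.15 log units; within the scatter), and a 1.5-fold lower number from compound 1 to compound 4 (0.18 log units; within the scatter). At this place, then, the exchange of 2-methoxyphenyl, with its hydrogen-bond acceptor, for 3-chlorophenyl, with none, is not tied to a clear change in the number, even though the gain of the methoxy on compound 1 gave a step beyond the scatter. Against compound 2 the reading is an at least 1.6-fold lower number from compound 2 to compound 4 (0.22 log units; that floor lies within the scatter), and compound 2 itself gives only a limit: the limit of > 30 mg/kg in this assay, at which 1 of the 4 values shown sits.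

Going by these compounds, whether a nitrile, a trifluoromethyl or a carboxylic acid in place of the chloro would move the number beyond the scatter remains open. Also open, on these data alone, is what a benzyl group or a longer chain would give in place of the aryl group on that ring nitrogen.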